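From methoxycarbonyl to carboxy: compound 1 and compound 4

The compounds below may be only part of what the source reports. "The series", "measured", "known", "first", "only" and "open" are said of these compounds alone.

Measured in a functional assay on SK-MEL cells (Homo sapiens) for cytotoxicity, read by MTT assay, with a stated time of 6 days; a higher number here means that more compound is needed for the effect, a lower number that less compound is needed:
- compound 1 `COC(=O)c1c(-c2ccc([N+](=O)[O-])cc2)oc2ccccc2c1=O` gives > 25 ug/mL, a limit
- compound 2 `COC(=O)c1c(-c2ccc([N+](=O)[O-])cc2)oc2cc(OC)ccc2c1=O` gives 2.84 ug/mL
- compound 3 `COC(=O)c1c(-c2ccc(OCc3ccccc3)cc2)oc2ccccc2c1=O` gives > 25 ug/mL, a limit

Compound 1 has no number of its own and stands at the limit of > 25 ug/mL in this assay, at which 2 of the 3 values shown sit. Compound 4 `O=C(O)c1c(-c2ccc([N+](=O)[O-])cc2)oc2ccccc2c1=O` has not yet been measured. It departs from compound 1 by one small change, (hydrogen in place of methyl on an oxygen next to a carbonyl group), with hydrogen in place of methyl on an oxygen next to a carbonyl group, so that methoxycarbonyl becomes carboxy.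

Neither measured step touches that place. Methoxy in place of hydrogen on an aromatic carbon gave an at least 8.8-fold lower number from compound 1 to compound 2 (0.94 log units; beyond the scatter), and benzyloxy in place of nitro gave a step that the two limits leave unreadable from compound 1 to compound 3. Neither step therefore gives a size for this change. Among the measured compounds shown here, with only the step to compound 2 leaving the limit, and nothing to suggest a similar move here, no readable step is expected in this assay, and compound 4 is expected to stay near the limit of compound 1.

The expected outcome is a step that the limit leaves unreadable from compound 1 to compound 4.
For compound 4 the estimated value is 40 ug/mL, with an expected range from 10 ug/mL to 100 ug/mL.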

Compound 4, concentration for half-maximal effect: > 25 ug/mL
Compound 4 ended at the assay's limit; the forecaster's own chance of this, stated with the estimate: 75%; the middle value lies beyond the limit too.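

No step can be read between compound 1 and compound 4, as both stand at a limit in this assay: the limit of > 25 ug/mL in this assay, at which 3 of the 4 values shown sit.

The compounds shown leave open whether carboxy in place of methoxycarbonyl shifts the number in this assay at all, as no pair with this change gives readable values.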